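This account rests on a few compounds, and the source may have more. Where it says the series, first, only, none or still open, it means among the compounds named here.

Measured compounds:
- compound 1, `O=[N+]([O-])c1ccc2c(c1)CN(c1ncnc3c1ncn3[C@@H]1O[C@H](CO)[C@@H](O)[C@H]1O)CC2`: 5.5 nM
- compound 2, `O=[N+]([O-])c1cccc2c1CCN(c1ncnc3c1nc1n3[C@@H]3O[C@H](CO1)[C@@H](O)[C@H]3O)C2`: 7410000 nM
- compound 3, `OC[C@H]1O[C@@H](n2cnc3c(SCC4CCCCC4)ncnc32)[C@H](O)[C@@H]1O`: 1550 nM

Notes on the series. The read-out throughout is an assay on isolated protein for binding affinity to Equilibrative nucleoside transporter 1 (Homo sapiens); a lower number here means a stronger inhibitor, a higher number a weaker inhibitor. Compound 3 sits second highest of the three numbers: in this assay compound 3 gives 1550 nM. Its nearest neighbour is compound 1, which in this assay gives 5.5 nM, a clearly lower number, beyond the scatter. Compound 2 lies furthest away; in this assay compound 2 gives 7410000 nM, a far higher number, again beyond the scatter. Going by the values given here, no single-change step between measured compounds is available, so no measured step size anchors the next move.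

Compound 4, `OC[C@H]1O[C@@H](n2cnc3c(SCCCc4ccccc4)ncnc32)[C@H](O)[C@@H]1O`, is not yet measured. It differs from compound 3 by phenethyl in place of cyclohexyl on a saturated chain carbon bound to a sulfur. Among the compounds with values here, the measured compounds give no direct precedent for this change, so the expected step in this assay is small, on either side, and quite possibly within the scatter; if anything, a modest move toward a lower number is expected. The estimated step is a 1.6-fold lower number from compound 3 to compound 4 (0.19 log units; within the scatter). For compound 4 the estimate in this assay is 1000 nM, with a range from 200 nM to 6000 nM.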

Compound 4, half-maximal inhibitory concentration: 1350 nM
Compound 4: middle estimate off by 1.4-fold (0.13 log units), on the low side; measured number inside the range.
By their numbers in this assay, from the lowest: compound 1; then compounds 4 and 3 (each within the scatter of the next); then compound 2.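

In this assay, the step of a 1.1-fold lower number from compound 3 to compound 4 (0.06 log units; within the scatter) comes with phenethyl in place of cyclohexyl on a saturated chain carbon bound to a sulfur. Going by these compounds alone, at this place, then, a six-membered aromatic ring on the longer 3-phenylpropyl chain and a six-membered non-aromatic ring on cyclohexylmethyl are not told apart by this read-out, which is the first single-change reading. Nothing at hand explains this result. 

On these data alone, whether an amine or a carboxylic acid at the end of the chain, or a chain longer than 3-phenylpropyl, moves the number at this place remains open. Within the data shown here, no single-change step yet links either sulfur-linked compound to compound 1, at 5.5 nM, so that gap cannot be assigned to any one structural difference.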